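A few compounds are considered here, and "the series" means these few. Any claim that something is new, unique, unknown or untested is made for them only; others in the source may bear on it.

Measured so far, in an assay on isolated protein with Polyunsaturated fatty acid 5-lipoxygenase (Homo sapiens) as the target; on this read-out higher numbers stand for weaker inhibition and lower numbers for stronger inhibition:
compound 1 `CC(O)c1cc(-c2ccccc2)c2ccc(OCc3cccc(C4(O)CCOCC4)c3)cc2c1` gives 520 nM;
compound 2 `CC(=O)c1cc(-c2ccccc2)c2ccc(OCc3cccc(C4(O)CCOCC4)c3)cc2c1` gives 130 nM;
compound 3 `CC1(C)COC(c2cc(-c3ccoc3)c3ccc(OCc4cccc(C5(O)CCOCC5)c4)cc3c2)=N1` gives 190 nM.

Compound 3 stands second highest of the three numbers; its value and that of compound 2 lie within the scatter of each other, whereas the number of compound 1 lies beyond the scatter above it. Compound 4 `OC1(c2cccc(COc3ccc4c(-c5ccoc5)cc(Cc5nccs5)cc4c3)c2)CCOCC1` differs from compound 3 in one place: a group of 6 heavy atoms (4 carbon, 1 nitrogen, 1 sulfur; one five-membered aromatic ring with 2 hetero atoms) in place of a group of 7 heavy atoms (5 carbon, 1 nitrogen, 1 oxygen; one five-membered non-aromatic ring with 2 hetero atoms), on an aromatic carbon. Among the measured compounds shown here, the only measured step, a 4.0-fold lower number from compound 1 to compound 2 (0.60 log units; beyond the scatter), swaps two different groups at the same place of the core, so it offers no direct guide to this exchange. For the measured compounds named here, with no matching precedent, a step of a 1.3-fold higher number from compound 3 to compound 4 (0.12 log units; within the scatter) is expected, within the scatter. Compound 4 is therefore estimated at 250 nM, with a range from 80 nM to 800 nM.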

Compound 4, half-maximal inhibitory concentration: 140 nM
For compound 4 the middle estimate is 1.8-fold (0.25 log units) above the measured one; low and high end bracket the measured number.
By their numbers in this assay, from the lowest: compounds 2, 4 and 3 (each within the scatter of the next); then compound 1.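

Putting (1,3-thiazol-2-yl)methyl in place of the non-aromatic ring group gives a 1.4-fold lower number from compound 3 to compound 4 (0.13 log units; within the scatter) in this assay, so this position, meta to a furan-3-yl group, accepts two quite different groups with no change beyond the scatter. Here an aromatic ring with sulfur serves as well as a non-aromatic ring with oxygen. Nothing available explains this result. Still open, going by these compounds, is whether an amine or a carboxylic acid at this position would keep the number in this range, and whether (1,3-thiazol-2-yl)methyl would do the same with phenyl in place of furan-3-yl.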